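Permeability notes: pyridyl to tert-butyl step on the shared core

The compounds below may be only part of what the source reports. "The series", "measured", "known", "first", "only" and "open" are said of these compounds alone.

Measured so far in an ADME assay on Caco-2 cells (Homo sapiens) for permeability, read by LC-MS, in the apical to basolateral direction, with a stated time of 60 min, at pH 6.5; a higher number here means that the compound crosses the layer faster, a lower number that the compound crosses the layer more slowly:
compound 1 `O=C(NCc1cc(Cl)ccc1-n1cnnn1)[C@@H]1C[C@@H]2C[C@@H]2N1C(=O)[C@H](O)Cc1ccccn1` gives 1.2 10^-6 cm/s
compound 2 `O=C(NCc1cc(Cl)ccc1-n1cnnn1)[C@@H]1CC=NN1C(=O)[C@H](O)C1CCCCC1` gives 19 10^-6 cm/s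
compound 3 `O=C(NCc1cc(Cl)ccc1-n1cnnn1)[C@@H]1[C@@H]2C[C@@H]2CN1C(=O)[C@H](O)c1ccccc1` gives 2.2 10^-6 cm/s

Compound 1 stands lowest of the three numbers in this assay. Compound 3 lies within the scatter of compound 1, so no order between the two can be read; compound 2 lies beyond the scatter above both. Compound 4 `CC(C)(C)C[C@@H](O)C(=O)N1[C@H](C(=O)NCc2cc(Cl)ccc2-n2cnnn2)C[C@@H]2C[C@@H]21` has not been measured. It differs from compound 1 by tert-butyl in place of pyridin-2-yl on a saturated chain carbon, two bonds along the chain from a carbonyl carbon and an oxygen on a saturated carbon. For the measured compounds named here, no step between measured compounds covers this change, so the expectation rests only on the spread seen across the three measured compounds. A rise beyond the scatter is expected, a 5.0-fold higher number from compound 1 to compound 4 (0.70 log units; beyond the scatter). The estimate for compound 4 is 6 10^-6 cm/s, with a range from 2 10^-6 cm/s to 18 10^-6 cm/s.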

Compound 4, apparent permeability: 25 10^-6 cm/s
Beside the measured number, compound 4's estimate is 4.2-fold (0.62 log units) below it; measured number outside the range, above it.
By their numbers in this assay, from the lowest: compounds 1 and 3 (each within the scatter of the next); then compounds 2 and 4 (each within the scatter of the next).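

On the shared core, tert-butyl in place of pyridin-2-yl on a saturated chain carbon gives, in this assay, a 21-fold higher number from compound 1 to compound 4 (1.32 log units; beyond the scatter). For the compounds shown here, this is the first single-place change, and it shows that this position alone can carry a large step. No measurement shown bears on the reason for it. Still open, going by these compounds, is whether a benzyl group in place of the (pyridin-2-yl)methyl would read closer to compound 1 or to compound 4. On these data alone, an amine or a longer chain at this position also remains untested in these notes, as does the same change on other cores.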